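The source may hold more compounds than are shown below. What is called first, only, known or untested is meant among the compounds shown, and "the series" means these compounds.

The study concerns two measured compounds and one still untested, all built on the same shared core. Compound 1 has the structure `COc1cc(-c2nn(-c3cccc(NC(=O)Nc4cc(C(F)(F)F)cc(C(F)(F)F)c4)c3)cc2-c2ccncc2)ccc1Cl` and compound 2 the structure `COc1cc(-c2nn(-c3cccc(NC(=O)c4cccc(C(F)(F)F)c4)c3)cc2-c2ccncc2)ccc1Cl`. In a functional assay on PC-3 cells (Homo sapiens) for inhibition, read by sulforhodamine B assay, with a stated time of 48 h (on this read-out lower numbers stand for higher toxicity in this test and higher numbers for lower toxicity in this test), compound 1 reaches only the limit of the test, > 50000 nM. In this assay compound 2 likewise reaches only the limit, > 50000 nM. On the numbers shown, compound 2 stands apart from nothing: both values are limits, and the limit of > 50000 nM in this assay, at which 2 of the 2 values shown sit, describes the whole picture. Compound 3, the unmeasured one, has the structure `COc1cc(-c2nn(-c3cccc(NC(=O)Nc4ccc(Cl)c(Cl)c4)c3)cc2-c2ccncc2)ccc1Cl`. It differs from compound 2 by (3,4-dichlorophenyl)amino in place of 3-(trifluoromethyl)phenyl on a carbonyl carbon. For the measured compounds named here, no step between measured compounds is available, so the size of any step can only be estimated. The step from compound 2 to compound 3 is expected to be none beyond the scatter, a step that the limit leaves unreadable from compound 2 to compound 3, with the result most likely ending at the limit again. Compound 3 is therefore expected to give about 60000 nM in this assay, within a range from 20000 nM to 200000 nM.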

Compound 3, concentration lethal to 50% of the cells: > 50000 nM
Compound 3 was reported as a limit; the forecaster's own chance of this, stated with the estimate: 80%; the middle value is on the limit's open side.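

For the compounds shown here, no step from compound 2 to compound 3 can be read in this assay, as both results are limits and not numbers. The compounds shown leave open how far compound 1, compound 2 and compound 3 each lie past that limit, and whether any structural difference among them affects the read-out: the limit of > 50000 nM in this assay, at which 3 of the 3 values shown sit.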